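A few compounds are considered here, and "the series" means these few. Any claim that something is new, unique, unknown or untested is made for them only; others in the source may bear on it.

Going by the values given here, compound 1 `COc1cc(C(=O)N2CCCC2)ccc1-c1ccnc2[nH]c(C3CCOCC3)cc12` gives 15 uL/min in an ADME assay on cells (Hepatocyte, Rattus norvegicus) for metabolic stability (a higher number here means faster removal of the compound, a lower number slower removal), and stands second highest of the three numbers so far. Compound 3 `COc1cc(F)ccc1-c1ccnc2[nH]c(C3CCOCC3)cc12` gives 97 uL/min, the higher of the other two numbers, and compound 2 `CN(C)C(=O)CN1CCC(c2cc3c(-c4ccc(=O)n(C5CCOCC5)c4)ccnc3[nH]2)CC1` gives 2.3 uL/min, the lower of the two. Among the compounds with values here, the one single-point step in the set runs a 6.5-fold higher number from compound 1 to compound 3 (0.81 log units; beyond the scatter), an exchange at the amide end of the core. Compound 4 `COc1cc(C(=O)N2CCCC2)ccc1-c1ccnc2[nH]c(C3CCNCC3)cc12` alters a different site: piperidin-4-yl in place of oxan-4-yl on an aromatic carbon. Within the data shown here, no measured step concerns this exchange, so nothing in the set predicts its direction. The working expectation for compound 4 is therefore a step of a 1.3-fold lower number from compound 1 to compound 4 (0.10 log units; within the scatter), that is, none beyond the scatter. Compound 4 is estimated at 12 uL/min in this assay, within a range of 5 uL/min to 30 uL/min.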

Compound 4, intrinsic clearance in a liver preparation (reported as CLH), per the amount of preparation that the assay uses: < 1 uL/min
Compound 4: a limit, no number; the forecaster's own chance of this, stated with the estimate: 5%; middle value at least 12-fold (1.07 log units) from the limit.
By their numbers in this assay, from the lowest: compound 2; then compound 1; then compound 3. At a limit, below all of these: compound 4.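

The position on the aromatic carbon next to the ring nitrogen, untouched by the earlier step, carries a large effect in this assay: an at least 15-fold lower number from compound 1 to compound 4 (1.17 log units; beyond the scatter). The two rings match in size and heavy atoms; they differ in the hetero atom, oxygen against nitrogen, and in the hydrogen-bond donor that enters. Compound 4 gives a limit, not a number: the limit of < 1 uL/min in this assay, at which 1 of the 4 values shown sits.

From the compounds shown here alone, the full size of the step therefore stays open. Also open, going by these compounds, is whether 1-methylpiperidin-4-yl or an open-chain amine such as aminomethyl at this position would give a step of similar size.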